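The compounds below may be only part of what the source reports. "The series", "measured", "known", "first", "only" and "open" are said of these compounds alone.

Working notes on the shared core of compound 1 `COc1cc2c(cc1OC)C(=O)C(C(=O)Nc1ccccc1)C2`, which in a physicochemical assay, with a stated time of 30 min (on this read-out lower numbers stand for stronger inhibition and higher numbers for weaker inhibition), gives 61.3 ug/mL. Compound 2 `CCc1ccc(NC(=O)C2Cc3cc(OC)c(OC)cc3C2=O)cc1` gives 76.2 ug/mL, and compound 3 `COc1ccc(NC(=O)C2Cc3cc(OC)c(OC)cc3C2=O)cc1` gives 49.5 ug/mL. Among these three numbers compound 1 stands second highest, and every step between the measured compounds lies within the scatter: a 1.2-fold higher number from compound 1 to compound 2 (0.09 log units; within the scatter), a 1.2-fold lower number from compound 1 to compound 3 (0.09 log units; within the scatter), a 1.5-fold lower number from compound 2 to compound 3 (0.19 log units; within the scatter). Compound 4 `CCOc1cccc(NC(=O)C2Cc3cc(OC)c(OC)cc3C2=O)c1` is the next case; relative to compound 1 it carries ethoxy in place of hydrogen on an aromatic carbon. Going by the values given here, the steps that bear on this change are the two other single additions on the same ring, both within the scatter, so no step beyond the scatter is expected in either direction in this assay. For compound 4 the expected step is a 1.1-fold lower number from compound 1 to compound 4 (0.02 log units; within the scatter). Compound 4 is therefore estimated at 58 ug/mL, ranging from 30 ug/mL to 110 ug/mL.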

Compound 4, half-maximal inhibitory concentration: 44.9 ug/mL
Beside the measured number, compound 4's estimate is 1.3-fold (0.11 log units) above it; the range from low to high includes it.
By their numbers in this assay, from the lowest: compounds 4, 3, 1 and 2 (each within the scatter of the next).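

With ethoxy in place of hydrogen, meta to a large group, this assay shows a 1.4-fold lower number from compound 1 to compound 4 (0.14 log units; within the scatter). Unlike the ethyl and methoxy steps, this one shows that an addition of 3 heavy atoms at this place on the six-membered aromatic ring leaves the read-out within the scatter of the unsubstituted compound. All three single additions to compound 1 now stay within the scatter, and none of the compounds shown goes against this.

On these data alone, whether an amine, a carboxylic acid or a longer chain at this place would give a step beyond the scatter remains open. No measurement on hand accounts for the size of this step.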